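From compound 2 to compound 3: an expected tolerance

A few compounds are considered here, and "the series" means these few. Any claim that something is new, unique, unknown or untested is made for them only; others in the source may bear on it.

Compound 1 `Cc1cc(S(N)(=O)=O)ccc1NC(=O)COc1ccc(Cl)cc1NC(=O)c1cccc(Cl)c1` gives 59700 nM
Compound 2 `Cc1cc(C)cc(C(=O)Nc2cc(Cl)ccc2OCC(=O)Nc2ccc(S(N)(=O)=O)cc2C)c1` gives 36500 nM

Among the measured compounds shown here, in a functional assay on C8166 cells (Homo sapiens) for cytotoxicity, read by MTT assay (a lower number here means that less compound is tolerated, a higher number that more compound is tolerated), compound 2 sits within the scatter of compound 1, the only other measured compound. Compound 3 `Cc1cc(S(N)(=O)=O)ccc1NC(=O)COc1ccc(Cl)cc1NC(=O)c1cc(Cl)cc(C#N)c1` carries 3-chloro-5-cyanophenyl in place of 3,5-dimethylphenyl on a carbonyl carbon. For the measured compounds named here, one measured step bears on this place: a 1.6-fold lower number from compound 1 to compound 2 (0.21 log units; within the scatter), with 3,5-dimethylphenyl in place of 3-chlorophenyl. On that single step, no change beyond the scatter is expected, and the expected size is a 1.2-fold higher number from compound 2 to compound 3 (0.09 log units; within the scatter). For compound 3 the estimated value is 45000 nM, with an expected range from 18000 nM to 110000 nM.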

Compound 3, half-maximal cytotoxic concentration: 131000 nM
Beside the measured number, compound 3's estimate is 2.9-fold (0.46 log units) below it, outside the stated range (above it).
By their numbers in this assay, from the lowest: compounds 2 and 1 (each within the scatter of the next); then compound 3.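

In this assay, the aryl group on the carbonyl carbon now shows a step beyond the scatter: 3-chloro-5-cyanophenyl in place of 3,5-dimethylphenyl gives a 3.6-fold higher number from compound 2 to compound 3 (0.55 log units; beyond the scatter), toward more compound tolerated. Cyano in place of hydrogen on an aromatic carbon gives a 2.2-fold higher number from compound 1 to compound 3 (0.34 log units; beyond the scatter), so that one added group is enough for a modest step in the same direction. Nothing available gives a reason for this shift. The compounds shown leave open whether cyano needs the chlorine alongside it to produce this step. They also leave open whether an amine or a carboxylic acid in its place would move the number the same way.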